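A few compounds are considered here, and "the series" means these few. Any claim that something is new, unique, unknown or untested is made for them only; others in the source may bear on it.

Compound 1 `O=c1c2ccccc2c(Cc2ccc(Cl)cc2)nn1-c1ccc(Br)cc1`: 91800 nM
Compound 2 `C=CCn1nc(Cc2ccc(OC)cc2)c2ccccc2c1=O`: 68600 nM

In an ADME assay for cytotoxicity, read by propidium iodide staining (on this read-out higher numbers stand for lower toxicity in this test and lower numbers for higher toxicity in this test), compound 2 gives 68600 nM. This lies within the usual scatter of compound 1 at 91800 nM, so the two numbers cannot be ranked.

Compound 3 `CCn1nc(Cc2ccc(OC)cc2)c2ccccc2c1=O`, not yet measured, differs from compound 2 in one place: methyl in place of vinyl on a saturated chain carbon bound to an aromatic nitrogen. In words, this is methyl in place of vinyl on a saturated chain carbon bound to an aromatic nitrogen, which turns allyl into ethyl.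

Within the data shown here, no measured pair of compounds shows this change, so there is no direct guide to its effect. Compound 2 differs from compound 1 in more than one place, yet compound 1 gives 91800 nM. On that basis, no step beyond the scatter is expected in this assay. The expected step is a 1.1-fold higher number from compound 2 to compound 3 (0.04 log units; within the scatter). For compound 3 the estimated value is 75000 nM, with an expected range of 40000 nM to 140000 nM.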

Compound 3, half-maximal cytotoxic concentration: 89500 nM
Estimate against measurement, compound 3: 1.2-fold (0.08 log units) below, and the stated range covers the measured number.
By their numbers in this assay, from the lowest: compounds 2, 3 and 1 (each within the scatter of the next).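

In this assay, ethyl in place of allyl gives a 1.3-fold higher number from compound 2 to compound 3 (0.12 log units; within the scatter). This is the first pair shown that differs in one place only, so the group on this saturated chain carbon bound to an aromatic nitrogen can now be read on its own. Removing one carbon and the double bond outside aromatic rings gives no difference that this test can separate from scatter, and nothing measured here offers an explanation for that result.

Going by these compounds, whether a longer chain such as butyl, or a chain ending in an amine or a carboxylic acid, would also stay within the scatter in this assay remains open. Compound 1 differs from both compound 2 and compound 3 in more than one place, so it cannot show how its other groups act on their own.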